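Series notes: third methoxy on the carbonyl-side ring

The source may hold more compounds than are shown below. What is called first, only, known or untested is meant among the compounds shown, and "the series" means these compounds.

Measured so far:
compound 1, `COc1cc(-c2cc(/C=C/C(=O)c3ccc(N)cc3)[nH]n2)cc(OC)c1OC`, in a functional assay on SK-MEL-2 cells (Homo sapiens) for cytotoxicity, read by sulforhodamine B assay, with a stated time of 48 h, tested at 10 uM (on this read-out lower numbers stand for a stronger effect and higher numbers for a weaker effect at the one concentration tested), gives -15%
compound 2, `COc1ccc(C(=O)/C=C/c2cc(-c3cc(OC)c(OC)c(OC)c3)n[nH]2)cc1OC`, in this assay gives -81%
compound 3, `COc1cc(-c2cc(/C=C/C(=O)c3ccc(F)c(F)c3)[nH]n2)cc(OC)c1OC`, in this assay gives -28%

Compound 2 stands lowest of the three numbers in this assay. The nearest number is that of compound 3, reached by a number 53 percentage points higher from compound 2 to compound 3 (beyond the scatter). The furthest is that of compound 1: a number 66 percentage points lower from compound 1 to compound 2 (beyond the scatter). The remaining step, a number 13 percentage points lower from compound 1 to compound 3 (beyond the scatter), is the only modest one.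

Compound 4, `COc1cc(C(=O)/C=C/c2cc(-c3cc(OC)c(OC)c(OC)c3)n[nH]2)cc(OC)c1OC`, differs from compound 2 in one place on the ring attached to the carbonyl carbon: methoxy in place of hydrogen on an aromatic carbon.

Every measured step exchanges the whole ring on the carbonyl carbon; none adds a single methoxy to a ring that already carries two. The large sizes of a number 66 percentage points lower from compound 1 to compound 2 (beyond the scatter) and a number 53 percentage points higher from compound 2 to compound 3 (beyond the scatter) show that this ring governs the read-out strongly, but they give no direction for a third methoxy. Compound 2 already sits at -81%, so little room remains downward. The expected step is therefore a number 4 percentage points lower from compound 2 to compound 4 (within the scatter), within the scatter or slightly lower. Compound 4 is estimated at -85%, with a range from -100% to -60%.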

Compound 4, a percentage reported as activity, at one concentration (the size of the read-out at that concentration, not a potency): -63%
The estimate for compound 4 lay 22 percentage points below the measured number; the measured number falls inside the stated range.
By their numbers in this assay, from the lowest: compound 2; then compound 4; then compound 3; then compound 1.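

In this assay, the addition of one methoxy to a ring that already carries two gives a number 18 percentage points higher from compound 2 to compound 4 (beyond the scatter), so the read-out responds to a single small change on this ring and not only to exchange of the whole ring. Among these compounds, this also supplies the direction that the earlier steps could not: at this aromatic carbon, ortho to a methoxy group and meta to a large group, methoxy in place of hydrogen weakens the effect at the one concentration tested, though by less than the whole-ring exchange in a number 66 percentage points lower from compound 1 to compound 2 (beyond the scatter). Nothing available here accounts for this weakening.

The compounds shown leave open whether the step belongs to methoxy itself or would follow any group at this aromatic carbon, a question that a hydroxy group, a fluorine atom or an ethoxy group in the same place would help to settle. From the compounds shown here alone, with one cell line and one concentration, it also remains open whether the weaker effect at that concentration would hold at other concentrations or would appear in other cell lines.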